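Isopropoxy to 2,2,2-trifluoroethoxy on the shared core

The compounds below may be only part of what the source reports. "The series", "measured", "known", "first", "only" and "open" are said of these compounds alone.

- compound 1 `COc1cc(-c2nnc3c(OCC(F)(F)F)cc(-c4ccc5[nH]ccc5c4)cn23)cc(OC)c1OC` gives 348 nM
- compound 2 `COc1cc(-c2nnc3c(OC(C)C)cc(-c4ccc5c(ccn5C)c4)cn23)cc(OC)c1OC` gives 503 nM

In a functional assay on HeLa cells (Homo sapiens) for antiproliferative activity, read by MTT assay, with a stated time of 48 h (a higher number here means a weaker inhibitor, a lower number a stronger inhibitor), compound 2 gives 503 nM, within the scatter of compound 1 at 348 nM. Compound 3 `COc1cc(-c2nnc3c(OCC(F)(F)F)cc(-c4ccc5c(ccn5C)c4)cn23)cc(OC)c1OC` carries 2,2,2-trifluoroethyl in place of isopropyl on an oxygen on an aromatic ring. Within the data shown here, no measured pair isolates this change. Compound 1 also carries 2,2,2-trifluoroethyl and gives 348 nM, so no change beyond the scatter is expected. The expected step, a 1.3-fold lower number from compound 2 to compound 3 (0.10 log units; within the scatter), is small and slightly downward. The estimate for compound 3 is 400 nM, with an expected range of 170 nM to 950 nM.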

Compound 3, half-maximal inhibitory concentration: 199 nM
For compound 3 the middle estimate is 2.0-fold (0.30 log units) above the measured one; the range from low to high includes it.
By their numbers in this assay, from the lowest: compounds 3, 1 and 2 (each within the scatter of the next, the first and the last beyond it).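

In this assay, 2,2,2-trifluoroethyl in place of isopropyl on an oxygen on an aromatic ring now stands as an isolated change, giving a 2.5-fold lower number from compound 2 to compound 3 (0.40 log units; beyond the scatter) with the rest of the structure held constant. Methyl in place of hydrogen on an aromatic nitrogen, with 2,2,2-trifluoroethoxy kept, gives a 1.7-fold lower number from compound 1 to compound 3 (0.24 log units; within the scatter), so this nitrogen shows no step beyond the scatter. Nothing measured here accounts for the step at the oxygen. Open, on these data alone, is whether a longer chain or a chain ending in an amine on that oxygen would hold this level. Also open, as far as these compounds go, is whether the step carries over to compounds with hydrogen on the aromatic nitrogen.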